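Imidazole in Place of Oxadiazolone on the Shared Core

The compounds below may be only part of what the source reports. "The series", "measured", "known", "first", "only" and "open" are said of these compounds alone.

Measured compounds:
- compound 1, `CC(C)C(Cc1nnc[nH]1)c1ccc(-c2ccc3cccc(F)c3c2)[nH]c1=O`: 17 nM
- compound 2, `CC(C)C(Cc1nnn[nH]1)c1ccc(-c2ccc3cccc(F)c3c2)[nH]c1=O`: 134 nM
- compound 3, `CC(C)C(c1noc(=O)[nH]1)c1ccc(-c2ccc3cccc(F)c3c2)[nH]c1=O`: 41 nM

Three compounds share one core and differ only in the five-membered ring hung on the saturated chain carbon. In a functional assay on CHO cells for antagonist activity at prostaglandin E2 receptor EP3 subtype (Homo sapiens), read by cAMP accumulation (a lower number here means a stronger inhibitor, a higher number a weaker inhibitor), compound 3 gives 41 nM, the second highest number of the three: compound 1 sits at 17 nM and compound 2 at 134 nM.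

Compound 4, `Cc1c[nH]c(C(c2ccc(-c3ccc4cccc(F)c4c3)[nH]c2=O)C(C)C)n1`, is not yet measured. Its change from compound 3 is a group of 6 heavy atoms (4 carbon, 2 nitrogen; one five-membered aromatic ring with 2 hetero atoms) in place of a group of 6 heavy atoms (2 carbon, 2 nitrogen, 2 oxygen; one five-membered aromatic ring with 3 hetero atoms), on a saturated chain carbon bound to an aromatic carbon and a saturated chain carbon.

Going by the values given here, two measured steps bear on this. Swapping the triazole of compound 1 for the oxadiazolone of compound 3 gave a 2.4-fold higher number from compound 1 to compound 3 (0.38 log units; beyond the scatter), and swapping the tetrazole of compound 2 for the same oxadiazolone gave a 3.3-fold lower number from compound 2 to compound 3 (0.51 log units; beyond the scatter). Among the compounds with values here, the five-membered ring therefore moves the number only modestly in either direction, with the triazole the best of the three so far. The entering imidazole is an azole with two ring nitrogens, in kind nearer to the triazole of compound 1 than to the tetrazole of compound 2, so compound 4 is expected to land near compound 1, a step of a 1.6-fold lower number from compound 3 to compound 4 (0.21 log units; within the scatter) in this assay. Compound 4 is estimated at 25 nM, within 8 nM to 80 nM.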

Compound 4, half-maximal inhibitory concentration: 36 nM
Compound 4: the middle estimate sits 1.4-fold (0.16 log units) below what was measured; low and high end bracket the measured number.
By their numbers in this assay, from the lowest: compound 1; then compounds 4 and 3 (each within the scatter of the next); then compound 2.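

At this place, on a saturated chain carbon bound to an aromatic carbon and a saturated chain carbon, the 4-methyl-1H-imidazol-2-yl ring, built from carbon and nitrogen alone, replaces the oxadiazolone and gives a 1.1-fold lower number from compound 3 to compound 4 (0.06 log units; within the scatter) in this assay, so the two oxygens of the leaving group are not needed to hold the number in this range. Compared with the (1H-tetrazol-5-yl)methyl group, the imidazole gives a 3.7-fold lower number from compound 2 to compound 4 (0.57 log units; beyond the scatter), and compared with the (4H-1,2,4-triazol-3-yl)methyl group it gives a 2.1-fold higher number from compound 1 to compound 4 (0.33 log units; beyond the scatter), which places it inside the span set by those two groups. Both of those steps change the ring and remove the methyl link at once, so they cannot show which of the two changes moved the number.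

No measurement of any property of these groups accompanies the numbers, so the reason for these steps remains unknown. Still open, from the compounds shown here alone, are how the 4-methyl-1H-imidazol-2-yl ring would behave on a methyl link, what its methyl group contributes, and whether a carboxylic acid on the same chain carbon would hold the number.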